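Working notes: alkyl sulfone to difluorobenzyl sulfone

This account rests on a few compounds, and the source may have more. Where it says the series, first, only, none or still open, it means among the compounds named here.

Compound 1 `CCSc1nnc(COc2cc(C)c3c(C)cc(=O)oc3c2)o1` gives > 100000 nM in a functional assay on MCF7 cells (Homo sapiens) for antiproliferative activity, read by MTT assay, with a stated time of 24 h (a higher number here means a weaker inhibitor, a lower number a stronger inhibitor), a limit of the assay rather than a number.
Compound 2 `CCCSc1nnc(COc2cc(C)c3c(C)cc(=O)oc3c2)o1` gives > 100000 nM in this assay, again a limit.
Compound 3 `CCS(=O)(=O)c1nnc(COc2cc(C)c3c(C)cc(=O)oc3c2)o1` gives > 100000 nM in this assay, also a limit.

Compound 3 therefore stands at the limit of > 100000 nM in this assay, at which 3 of the 3 values shown sit. Compound 4 `Cc1cc(OCc2nnc(S(=O)(=O)Cc3ccc(F)c(F)c3)o2)cc2oc(=O)cc(C)c12` differs from it by 3,4-difluorophenyl in place of methyl on a saturated chain carbon bound to a sulfonyl sulfur; cut one bond further out, the same change reads ethyl to 3,4-difluorobenzyl.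

The measured steps that touch the same region are a step that the two limits leave unreadable from compound 1 to compound 3 and a step that the two limits leave unreadable from compound 2 to compound 3, both changes at the sulfur on the aromatic carbon, and a step that the two limits leave unreadable from compound 1 to compound 2, a lengthening of the chain on the sulfur. None of the three is readable in size, since both ends of each sit at the limit. Among the measured compounds shown here, no measured step therefore sets a size or direction for the change to compound 4, and the expectation for a number no higher from compound 3 to compound 4 (the limit leaves the size open) is a step not beyond the scatter, with the assay most likely again reporting only a limit.

Compound 4 is estimated at 100000 nM, expected range 30000 nM to 300000 nM.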

Compound 4, half-maximal inhibitory concentration: 55200 nM
The estimate for compound 4 lay 1.8-fold (0.26 log units) above the measured number; the range from low to high includes it.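

Among the compounds shown here, the chain carbon bound to the sulfonyl sulfur is the first place where a change yields a number rather than a limit in this assay: the limit of > 100000 nM in this assay, at which 3 of the 4 values shown sit. Going from ethyl to 3,4-difluorobenzyl gives an at least 1.8-fold lower number from compound 3 to compound 4 (0.25 log units; that floor lies within the scatter); the starting value is a limit of the assay, and the true size of the step stays open. The steps among the three earlier compounds cannot be read, and they gave no direction for a change at this position.

Open, going by these compounds, is whether a plain benzyl without fluorine on the sulfonyl sulfur would read like compound 4, or whether the 3,4-difluorophenyl group is needed. Also open, on these data alone, is how an amine or a carboxylic acid on that chain carbon would read.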